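Carboxy position on the fluorophenyl ether: compound 4

The source may hold more compounds than are shown below. What is called first, only, known or untested is meant among the compounds shown, and "the series" means these compounds.

Compound 1 `COc1ccc(C(=O)O)cc1O[C@H](C)COc1ccc(C(=O)CC(C)(C)C)c(O)c1C` gives 1850 nM in an assay for positive allosteric modulation of metabotropic glutamate receptor 3 (Rattus norvegicus); on this read-out higher numbers stand for an effect only at larger amounts of compound and lower numbers for an effect already at smaller amounts. Compound 2 `COc1ccc(C(=O)O)cc1OC[C@H](C)COc1ccc(C(=O)CC(C)(C)C)c(O)c1C` gives 384 nM. Compound 3 `Cc1c(OC[C@@H](C)COc2cc(C(=O)O)ccc2F)ccc(C(=O)CC(C)(C)C)c1O` gives 3950 nM, the highest of the three numbers; compound 1 sits nearest to it and compound 2 furthest. Among the measured compounds shown here, the single measured step, a 10-fold higher number from compound 2 to compound 3 (1.01 log units; beyond the scatter), exchanges fluoro for methoxy. Compound 4 `Cc1c(OC[C@@H](C)COc2ccc(C(=O)O)cc2F)ccc(C(=O)CC(C)(C)C)c1O` differs from compound 3 by 4-carboxy-2-fluorophenyl in place of 5-carboxy-2-fluorophenyl on an oxygen on a saturated carbon. For the measured compounds named here, no measured pair shares this change: the fluoro-for-methoxy step does not speak to where the carboxy stands, and compounds 1 and 2 carry it as compound 3 does. With nothing to lean on, no step beyond the scatter is expected in this assay. The estimated step is a 1.1-fold higher number from compound 3 to compound 4 (0.06 log units; within the scatter), held with wide uncertainty. Compound 4 is expected to give 4500 nM, between 1500 nM and 13000 nM.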

Compound 4, half-maximal effective concentration: 1300 nM
Compound 4: middle estimate off by 3.5-fold (0.54 log units), on the high side; measured number outside the range, below it.
By their numbers in this assay, from the lowest: compound 2; then compounds 4 and 1 (each within the scatter of the next); then compound 3.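

In this assay the place of the carboxy group on the fluorophenyl ether matters: with the same atoms joined differently, 4-carboxy-2-fluorophenyl in place of 5-carboxy-2-fluorophenyl gives a 3.0-fold lower number from compound 3 to compound 4 (0.48 log units; beyond the scatter). Among the compounds shown here, the earlier compounds held the carboxy group in one arrangement only, so this is the first read on its position. For the compounds shown here, nothing measured so far accounts for the shift.

Open, going by these compounds, is whether the methoxy group of compound 2 would do better than fluoro on the 4-carboxy-2-fluorophenyl as well. Also open, on these data alone, is whether an amide or a tetrazole could stand in for the carboxylic acid there.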